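Swapping fluoro for methoxy on a shared anilinopyrimidine-type core

The compounds below may be only part of what the source reports. "The series", "measured", "known", "first", "only" and "open" are said of these compounds alone.

Measured so far:
- compound 1, `Cc1ccc(-c2ccnc(Nc3cccc(N(C)C)c3)n2)s1`: 5700 nM
- compound 2, `Fc1ccc(Nc2nccc(-c3ccncc3)n2)cc1`: 1900 nM
- compound 3, `c1ccc(-c2ccnc(Nc3cccc(OCCn4ccnc4)c3)n2)nc1`: 400 nM

The three measured compounds share a common core and were tested in a functional assay for inhibition, with Homo sapiens as the target; on this read-out lower numbers stand for stronger inhibition and higher numbers for weaker inhibition. Among them compound 2 holds the second-highest number. Compound 1 sits nearest to it with a higher number, a gap that lies beyond the usual scatter, while compound 3 lies furthest away with a lower number, also beyond the scatter.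

Compound 4, `COc1ccc(Nc2nccc(-c3ccncc3)n2)cc1`, has not yet been measured. It differs from compound 2 in a single place: methoxy in place of fluoro on an aromatic carbon. Within the data shown here, no measured pair in this set shows a step of exactly this kind, so there is no direct precedent for its size. With only the change of a small group on the outer ring, the expectation is a step in this assay of no more than the usual scatter, in either direction. Compound 4 is therefore expected to give about 1500 nM, with a range from 500 nM to 4500 nM, which means an expected step of a 1.3-fold lower number from compound 2 to compound 4 (0.10 log units; within the scatter).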

Compound 4, half-maximal inhibitory concentration: 4200 nM
The estimate for compound 4 lay 2.8-fold (0.45 log units) below the measured number, within the range that was stated.
By their numbers in this assay, from the lowest: compound 3; then compound 2; then compounds 4 and 1 (each within the scatter of the next).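

In this assay putting methoxy in place of fluoro on an aromatic carbon, para to a large group, gives a 2.2-fold higher number from compound 2 to compound 4 (0.34 log units; beyond the scatter) and so means weaker inhibition. Among these compounds, this is the first comparison in the set in which only one place changes, and it shows that the group at this position can shift the number by a modest but real amount, with fluoro the better of the two groups. Nothing measured here explains why the number moves in this direction.

As far as these compounds go, two groups at one position cannot show a trend, so it remains open where chloro, a nitrile or an amine would fall at this spot. From the compounds shown here alone, it is also open whether the same swap would give a similar step on the cores of compound 1 or compound 3.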